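Methyl on the pyrazole nitrogen: a small step, little expected change

The source may report more compounds than this note shows. Statements on the series, on what has been measured and on what is new or still open speak of the compounds shown alone.

Measured compounds:
compound 1, `CN1CCN(c2ccc(NC(=N)c3cc4cn[nH]c4cn3)cc2)CC1`, 31300 nM
compound 2, `CN1CCN(c2ccc(NC(=N)c3cc4cn(C)nc4cn3)cc2)CC1`, 21000 nM

Both compounds were tested in a functional assay on HT-1080 cells (Homo sapiens) for cytotoxicity, read by MTT assay, with a stated time of 72 h (a higher number here means a weaker inhibitor, a lower number a stronger inhibitor), a test whose read-out is the half-maximal inhibitory concentration. Compound 1 gives 31300 nM and stands at the highest number of the two measured, while compound 2 with 21000 nM lies within the usual scatter of it, so the two cannot be told apart on these numbers.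

Compound 3, `CN1CCN(c2ccc(NC(=N)c3cc4cnn(C)c4cn3)cc2)CC1`, has not yet been measured. It differs from compound 1 by methyl in place of hydrogen on an aromatic nitrogen. Within the data shown here, with no measured pair showing this exact change, and the two measured compounds lying within the scatter of each other, no shift beyond the scatter is expected in this assay: the step of a 1.1-fold lower number from compound 1 to compound 3 (0.05 log units; within the scatter) is estimated to be small. Compound 3 is therefore expected to give 28000 nM, with a range from 10000 nM to 75000 nM.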

Compound 3, half-maximal inhibitory concentration: 24000 nM
For compound 3 the middle estimate is 1.2-fold (0.07 log units) above the measured one; the measured number falls inside the stated range.
By their numbers in this assay, from the lowest: compounds 2, 3 and 1 (each within the scatter of the next).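

In this assay methyl in place of the hydrogen on this aromatic nitrogen gives a 1.3-fold lower number from compound 1 to compound 3 (0.12 log units; within the scatter) and so leaves the number where it was, as far as this test can tell. The hydrogen at this position is therefore not needed to keep the modest cytotoxicity seen with compound 1, and the one added carbon brings no measurable loss or gain. Nothing available here explains why the change has so little effect.

Only hydrogen and methyl are shown on this nitrogen, so it remains open whether a longer chain such as propyl, a benzyl group or a chain ending in an amine would also leave the number unchanged. On these data alone, it is equally open whether any group at this position can move the number beyond the scatter.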